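The compounds below may be only part of what the source reports. "The series", "measured", "known", "first", "only" and "open" are said of these compounds alone.

Measured in a functional assay on MT4 cells (Homo sapiens) for cytotoxicity; a higher number here means that more compound is tolerated, a lower number that less compound is tolerated:
compound 1 `CC(c1ccccc1)c1cc(O)nc(SC2CCCCC2)n1` gives 149000 nM
compound 2 `CCC(c1ccccc1)c1cc(O)nc(SC2CCCCC2)n1` gives 51000 nM
compound 3 `Cc1c(O)nc(SC(C)C)nc1C(C)c1c(F)cccc1F` gives 200000 nM

From compound 1 to compound 2 the change is methyl in place of hydrogen on a saturated chain carbon, two bonds along the chain from two aromatic carbons, and the step is a 2.9-fold lower number from compound 1 to compound 2 (0.47 log units; beyond the scatter). Compound 3 stands at the high end of the three; its gap to compound 1 is within the scatter, its gap to compound 2 beyond it. The difference between the core of compound 3 and the core of compound 1 is not broken down here.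

Compound 4 `CCC(C)Sc1nc(O)c(C)c(C(C)c2c(F)cccc2F)n1` is not yet measured. It differs from compound 3 by methyl in place of hydrogen on a saturated chain carbon, two bonds along the chain from a sulfur, the same kind of change as from compound 1 to compound 2, though the place differs: there the methyl enters on a saturated chain carbon two bonds along the chain from two aromatic carbons, here two bonds along the chain from a sulfur. In this assay compound 4 is expected to show a 2.0-fold lower number from compound 3 to compound 4 (0.30 log units; within the scatter), resting on a 2.9-fold lower number from compound 1 to compound 2 (0.47 log units; beyond the scatter) and on compound 3 at 200000 nM, with some allowance for the different place. The estimate for compound 4 is 100000 nM, expected between 40000 nM and 250000 nM.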

Compound 4, half-maximal cytotoxic concentration: > 200000 nM
Compound 4: a limit, no number; the forecaster's own chance of this, stated with the estimate: 20%; at least 2.0-fold (0.30 log units) between middle value and limit.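

In this assay compound 4 gives > 200000 nM as a limit of the assay, not a number. The new step is a number no lower from compound 3 to compound 4 (the limit leaves the size open). The methyl in place of hydrogen does not carry over unchanged from one core to the other: the same change on two cores in this assay, a 2.9-fold lower number (0.47 log units; beyond the scatter) from compound 1 to compound 2 and a number no lower (the limit leaves the size open) from compound 3 to compound 4, at least 2.9-fold (0.46 log units) apart, beyond the scatter of two such steps. This does not show whether the core or the place of the methyl sets the two steps apart, as both differ, and the size of the new step cannot be read: the limit of > 200000 nM in this assay, at which 1 of the 4 values shown sits.

Open, on these data alone, is how the same methyl behaves on the core of compound 1 at the chain two bonds along from a sulfur. Also open, as far as these compounds go, is how a longer chain, an amine or a carboxylic acid in place of the sec-butyl would read.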